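This account rests on a few compounds, and the source may have more. Where it says the series, first, only, none or still open, it means among the compounds named here.

Compound 1 `Cc1ccccc1-c1nn(-c2ccc(F)cc2F)cc1CNCCN1CCN(C)CC1`: > 20000 nM in an ADME assay on Huh-7 cells (Homo sapiens) for cytotoxicity (a lower number here means that less compound is tolerated, a higher number that more compound is tolerated), a limit of the assay.
Compound 2 `Cc1ccc(-n2cc(CNCCN3CCN(C)CC3)c(-c3ccccc3C)n2)c(C)c1`: > 20000 nM in this assay, also a limit.
Compound 3 `Cc1ccccc1-c1nn(-c2ccc(Br)cc2)cc1CNCCN1CCN(C)CC1`: 9600 nM in this assay.

Going by the values given here, compound 3 holds the only number in this assay; the other two values sit at the limit of > 20000 nM in this assay, at which 2 of the 3 values shown sit. The steps into compound 3 are an at least 2.0-fold lower number from compound 1 to compound 3 (0.31 log units; beyond the scatter) and an at least 2.0-fold lower number from compound 2 to compound 3 (0.31 log units; beyond the scatter), while a step that the two limits leave unreadable from compound 1 to compound 2 stays unreadable between the two limits.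

Compound 4 `Cc1ccccc1-c1nn(-c2cccc(C(F)(F)F)c2)cc1CNCCN1CCN(C)CC1` carries the change (3-(trifluoromethyl)phenyl in place of 4-bromophenyl on an aromatic nitrogen). Among the compounds with values here, no measured step touches a 3-(trifluoromethyl)phenyl group, so the expectation rests only on the spread of compound 3 against compounds 1 and 2. Compound 4 is expected near compound 3, with the step of a 1.3-fold higher number from compound 3 to compound 4 (0.10 log units; within the scatter) counted as within the scatter, so the estimate for compound 4 is 12000 nM with a range of 5000 nM to 25000 nM.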

Compound 4, half-maximal cytotoxic concentration: 18000 nM
For compound 4 the middle estimate is 1.5-fold (0.18 log units) below the measured one; measured number inside the range.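

In this assay, 3-(trifluoromethyl)phenyl in place of 4-bromophenyl on the aromatic nitrogen gives a 1.9-fold higher number from compound 3 to compound 4 (0.27 log units; within the scatter), so the two groups cannot be told apart here. Against the other two compounds only floors can be read, an at least 1.1-fold lower number from compound 2 to compound 4 (0.04 log units; that floor lies within the scatter) and an at least 1.1-fold lower number from compound 1 to compound 4 (0.04 log units; that floor lies within the scatter), so compound 4 is not separated from them, as compound 3 was. Compound 1 and compound 2 remain limits of the assay: the limit of > 20000 nM in this assay, at which 2 of the 4 values shown sit.

Open, as far as these compounds go, is whether an amine or a carboxylic acid on this phenyl group would move the number beyond the scatter. Also open, from the compounds shown here alone, is how far compound 1 and compound 2 really lie from compound 4.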